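The compounds below may be only part of what the source reports. "The series", "measured", "known", "first", "only" and "open" are said of these compounds alone.

Of the compounds shown here, three that share one core have been measured in an assay on CHO cells with metabotropic glutamate receptor 5 (Homo sapiens) as the target; a lower number here means that less compound is needed, a higher number that more compound is needed for the effect. Compound 1 `O=C(Nc1cc(-c2ccccc2)nn1-c1ccccc1)c1ccc(F)c(F)c1` gives 10 nM. Compound 2 `O=C(Nc1cc(-c2ccccc2)nn1-c1ccccc1)c1ccc(F)cc1` gives 30 nM, and compound 3 `Cc1ccc(C(=O)Nc2cc(-c3ccccc3)nn2-c2ccccc2)cc1` gives 30 nM. The step from a 3.0-fold higher number from compound 1 to compound 2 (0.48 log units; beyond the scatter) and the step from a 3.0-fold higher number from compound 1 to compound 3 (0.48 log units; beyond the scatter) are both modest, whereas the step from no change at the digits printed from compound 2 to compound 3 (within the scatter) shows nothing. So compound 3 stands level with compound 2, and together they hold the highest numbers of the three, with compound 1 the only one that sits clearly lower.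

Compound 4 `O=C(Nc1cc(-c2ccccc2)nn1-c1ccccc1)c1ccccc1Cl` is the next compound to be measured. The change from compound 3 is 2-chlorophenyl in place of 4-methylphenyl on a carbonyl carbon. Within the data shown here, two measured steps bear on this exchange of one aryl group for another on the carbonyl carbon: the step from no change at the digits printed from compound 2 to compound 3 (within the scatter), where swapping one substituent for another left the number unchanged, and the step from a 3.0-fold higher number from compound 1 to compound 3 (0.48 log units; beyond the scatter), where the whole ring was exchanged and the number moved modestly. Among the measured compounds shown here, no measured compound carries a 2-chlorophenyl, so the step from compound 3 to compound 4 in this assay is expected to be small, at most modest in either direction, and most likely within the scatter. The expected step is a 1.5-fold higher number from compound 3 to compound 4 (0.18 log units; within the scatter). For compound 4 the estimate in this assay is 45 nM, with a range from 12 nM to 180 nM.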

Compound 4, half-maximal effective concentration: 2500 nM
For compound 4 the middle estimate is 56-fold (1.74 log units) below the measured one, outside the stated range (above it).
By their numbers in this assay, from the lowest: compound 1; then compounds 2 and 3 (each within the scatter of the next); then compound 4.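

In this assay, the aryl group on the carbonyl carbon matters far more than the first compounds suggested: the 3,4-difluorophenyl, 4-fluorophenyl and 4-methylphenyl groups lie only modestly apart at most, yet 2-chlorophenyl gives an 83-fold higher number from compound 3 to compound 4 (1.92 log units; beyond the scatter), together with an 83-fold higher number from compound 2 to compound 4 (1.92 log units; beyond the scatter) and a 250-fold higher number from compound 1 to compound 4 (2.40 log units; beyond the scatter). Heavy-atom count alone does not set the number at this place, as 4-methylphenyl and 2-chlorophenyl have the same count and neither carries a hydrogen-bond donor or acceptor, yet they sit at opposite ends of this large gap. No measurement at hand accounts for this large rise.

The 2-chlorophenyl group differs from the other three in both the substituent it carries and where that substituent sits on the ring, and the compounds shown cannot tell which of the two matters. A 4-chlorophenyl group on the same carbonyl carbon would test the chlorine without the change of place, while a 2-methylphenyl group would test the place with a substituent other than chlorine.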